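A few compounds are considered here, and "the series" means these few. Any claim that something is new, unique, unknown or untested is made for them only; others in the source may bear on it.

Compound 2 `C1=C(c2cncc(Oc3ccccc3)c2)CC2CNCC1C2` is the reference point of this small series. Among the compounds with values here, in an in vitro assay on SH-SY5Y cells for displacement of a labelled ligand from Neuronal acetylcholine receptor; alpha3/beta4 (Homo sapiens) (on this read-out lower numbers stand for stronger inhibition and higher numbers for weaker inhibition), compound 2 gives 1.9 nM, the lowest number among the three compounds measured so far. Compound 3 `FC(F)(F)c1cncc(C2=CC3CNCC(C2)C3)c1` comes nearest, giving 79 nM in this assay, and compound 1 `C1=C(c2cnccn2)CC2CNCC1C2` lies furthest away, giving 828 nM in this assay.

Within the data shown here, the one step that touches the phenoxy side of compound 2 is a 42-fold higher number from compound 2 to compound 3 (1.62 log units; beyond the scatter); it shows that exchanging the phenoxy group moves the number a long way. Among the measured compounds shown here, no measured step removes or alters a substituent on the phenoxy ring itself.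

Compound 4 `COc1ccc(Oc2cncc(C3=CC4CNCC(C3)C4)c2)cc1` carries the change (methoxy in place of hydrogen on an aromatic carbon), on the aromatic carbon of the six-membered ring of carbon only, para to a large group; the phenoxy ring remains in place. For the measured compounds named here, since the measured steps give no direct precedent for this addition, the step from compound 2 to compound 4 is estimated as small, expected as a 1.3-fold higher number from compound 2 to compound 4 (0.12 log units; within the scatter) in this assay. Compound 4 is expected to give about 2.5 nM in this assay, with a range from 0.8 nM to 8 nM.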

Compound 4, inhibition constant: 27 nM
Compound 4: middle estimate off by 11-fold (1.03 log units), on the low side, and the stated range ends below it.
By their numbers in this assay, from the lowest: compound 2; then compound 4; then compound 3; then compound 1.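

In this assay, the phenoxy ring is sensitive to change even when it stays in place: methoxy in place of hydrogen, on the aromatic carbon para to a large group, gives a 14-fold higher number from compound 2 to compound 4 (1.15 log units; beyond the scatter). The earlier step, a 42-fold higher number from compound 2 to compound 3 (1.62 log units; beyond the scatter), showed only that exchanging the whole phenoxy group moves the number a long way; this step shows that an addition of 2 heavy atoms to the ring can also move it well beyond the scatter, though by less than that exchange did. Nothing shown here offers an explanation for this rise in the number.

As far as these compounds go, it remains open whether the rise is specific to methoxy or would also follow from fluorine, a hydroxyl group or a longer chain such as butoxy on the same carbon. From the compounds shown here alone, the response of the other carbons of the phenoxy ring to substitution also remains open.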